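The source may report more compounds than this note shows. Statements on the series, on what has been measured and on what is new or still open speak of the compounds shown alone.

Compound 1, `CCOC(=O)c1ccc(-c2ccc(N(C)C)nn2)cc1`. In a functional assay on NCI-H727 cells (Homo sapiens) for antiproliferative activity, with a stated time of 48 h (on this read-out higher numbers stand for weaker inhibition and lower numbers for stronger inhibition), compound 1 gives > 25000 nM, which is a limit of the assay and not a number.
Compound 2, `CCOC(=O)c1ccc(-c2ccc(OCC)nn2)cc1`. In this assay compound 2 gives > 25000 nM, again a limit of the assay.
Compound 3, `CCOC(=O)c1ccc(-c2ccc(OC(C)C)nn2)cc1`, is not yet measured.

On the numbers shown, compound 2 stands at the limit, the same limit at which compound 1 sits (the limit of > 25000 nM in this assay, at which 2 of the 2 values shown sit). Within the data shown here, the only measured step, a step that the two limits leave unreadable from compound 1 to compound 2, joins two limits, so its size cannot be read from the data.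

The change from compound 2 to compound 3 is methyl in place of hydrogen on a saturated chain carbon bound to an oxygen on an aromatic ring and a saturated chain carbon. No measured step bears directly on this change: the one step shown concerns the swap of dimethylamino for ethoxy, not growth of the ethoxy chain itself. With both measured values at the limit and no readable step, there is no basis to expect movement in this assay beyond the scatter, in either direction, and the most likely outcome is that compound 3 also returns a limit.

Compound 3 is therefore estimated at 30000 nM, within 10000 nM to 100000 nM. The expected step that the limit leaves unreadable from compound 2 to compound 3 is no change beyond the scatter.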

Compound 3, half-maximal inhibitory concentration: > 25000 nM
Compound 3: a limit, no number; the forecaster's own chance of this, stated with the estimate: 85%; the middle value lies beyond the limit too.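

In this assay compound 3 gives > 25000 nM and this is a limit of the assay, not a number. The steps from compound 1 and from compound 2 to compound 3 therefore cannot be read, and all three compounds stand at one limit: the limit of > 25000 nM in this assay, at which 3 of the 3 values shown sit.

The compounds shown leave open whether dimethylamino, ethoxy and isopropoxy differ at all in this antiproliferative read-out.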